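Notes on the amide series: piperidine to piperazine step

This account rests on a few compounds, and the source may have more. Where it says the series, first, only, none or still open, it means among the compounds named here.

Compound 2 `COc1cc2c(Oc3ccc(NC(=O)c4cn(-c5ccccc5F)nn4)cc3F)ccnc2cc1OCCCN1CCC(C)CC1` gives the lowest number of the three measured in a functional assay on A549 cells (Homo sapiens) for cytotoxicity, read by MTT assay, with a stated time of 72 h (a higher number here means a weaker inhibitor, a lower number a stronger inhibitor), at 250 nM. Compound 1 `COc1cc2c(Oc3ccc(NC(=O)c4cn(-c5ccccc5F)nn4)cc3F)ccnc2cc1OCCCN1CCCCC1` gives 2770 nM in this assay, and compound 3 `COc1cc2c(Oc3ccc(NC(=O)c4cn(-c5ccccc5C)nn4)cc3F)ccnc2cc1OCCCN1CCC(C)CC1` gives 3500 nM. Both stand well apart from compound 2: an 11-fold lower number from compound 1 to compound 2 (1.04 log units; beyond the scatter), and a 14-fold higher number from compound 2 to compound 3 (1.15 log units; beyond the scatter). Compound 4 `COc1cc2c(Oc3ccc(NC(=O)c4cn(-c5ccccc5F)nn4)cc3F)ccnc2cc1OCCCN1CCN(C)CC1` has not yet been measured. It differs from compound 2 in one place: 4-methylpiperazin-1-yl in place of 4-methylpiperidin-1-yl on a saturated chain carbon, three bonds along the chain from an oxygen on an aromatic ring. Neither recorded step covers this change. The step from compound 1 to compound 2 concerned a methyl on a saturated ring carbon and was large; the step from compound 2 to compound 3 concerned the aromatic ring and was also large. Both show that single changes in this series move the number beyond the scatter, but nothing measured shows what replacing a ring carbon by a ring nitrogen does here. The expected step in this assay is therefore uncertain; a move away from the lowest number, of moderate size, is taken as the working expectation, a 3.2-fold higher number from compound 2 to compound 4 (0.51 log units; beyond the scatter). Compound 4 is accordingly estimated at 800 nM, with an expected range of 200 nM to 4000 nM.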

Compound 4, half-maximal inhibitory concentration: 250 nM
The estimate for compound 4 lay 3.2-fold (0.51 log units) above the measured number, within the range that was stated.
By their numbers in this assay, from the lowest: compounds 2 and 4 (each within the scatter of the next); then compounds 1 and 3 (each within the scatter of the next).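

At this position, on a saturated chain carbon, three bonds along the chain from an oxygen on an aromatic ring, 4-methylpiperazin-1-yl in place of 4-methylpiperidin-1-yl gives no change at the digits printed from compound 2 to compound 4 (within the scatter) in this assay, so this assay does not separate the two rings. The comparison with the unmethylated ring gives an 11-fold lower number from compound 1 to compound 4 (1.04 log units; beyond the scatter), which shows that the low number seen with 4-methylpiperidin-1-yl is also reached with 4-methylpiperazin-1-yl, although compound 3, which carries 4-methylpiperidin-1-yl and differs on the aromatic ring, goes against reading the number from this group alone. Nothing available explains why the two rings read alike.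

Still open, from the compounds shown here alone, is whether the methyl on the piperazine ring matters, which piperazin-1-yl itself or 4-ethylpiperazin-1-yl would address, and whether morpholin-4-yl at the same place would read like these rings. Also open, going by these compounds, is whether methyl in place of fluoro on the aromatic carbon gives a step of similar size when 4-methylpiperazin-1-yl is present.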